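A few compounds are considered here, and "the series" means these few. Any claim that something is new, unique, unknown or untested is made for them only; others in the source may bear on it.

Compound 1 `NS(=O)(=O)c1ccc(Nc2nccc(-c3ccccn3)n2)cc1`: 4600 nM
Compound 2 `COc1ccc(Nc2nccc(-c3ccccn3)n2)cc1`: 8300 nM

In a functional assay for inhibition, with Homo sapiens as the target (on this read-out higher numbers stand for weaker inhibition and lower numbers for stronger inhibition), compound 2 gives the highest of the two numbers; compound 1 is nearest, and the step of a 1.8-fold higher number from compound 1 to compound 2 (0.26 log units; within the scatter) lies within the scatter. Compound 3 `COc1ccc(Nc2nccc(-c3cccnc3)n2)cc1` differs from compound 2 by pyridin-3-yl in place of pyridin-2-yl on an aromatic carbon. Among the measured compounds shown here, the one measured step concerns a change at another part of the molecule and gives no guidance on this one, so no step beyond the scatter is expected in this assay in either direction, with a wide uncertainty. Compound 3 is expected to give 12000 nM, in a range from 3000 nM to 50000 nM. The expected step is a 1.4-fold higher number from compound 2 to compound 3 (0.16 log units; within the scatter).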

Compound 3, half-maximal inhibitory concentration: 1700 nM
Beside the measured number, compound 3's estimate is 7.1-fold (0.85 log units) above it; measured number below the stated range.
By their numbers in this assay, from the lowest: compound 3; then compounds 1 and 2 (each within the scatter of the next).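

In this assay, among the compounds shown here, the exchange of pyridin-2-yl for pyridin-3-yl gives a 4.9-fold lower number from compound 2 to compound 3 (0.69 log units; beyond the scatter), the first step beyond the scatter. It shows that this position, next to the ring nitrogen, responds to where the nitrogen sits in the pendant ring, even though the atom and hydrogen-bond counts stay the same. Nothing measured here accounts for this step. On these data alone, it remains open whether pyridin-4-yl or a phenyl ring would extend the trend at this position. Also open, as far as these compounds go, is whether an amine on the pyridin-3-yl ring would be tolerated, or how the sulfamoyl group would behave alongside pyridin-3-yl.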